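Replacing the aryl group of compound 2

The compounds below may be only part of what the source reports. "The series", "measured", "known", "first", "only" and "open" are said of these compounds alone.

- compound 1 (`CC/C(=C(\c1ccc2[nH]ncc2c1)c1ccc(/C=C/C(=O)O)cc1C)c1ccccc1`) at 36 nM
- compound 2 (`CC/C(=C(/c1ccc(/C=C/C(=O)O)cc1)c1ccc2[nH]ncc2c1)c1cccc(Cl)c1`) at 12 nM

In a functional assay on MCF7 cells (Homo sapiens) for cytotoxicity, read by CellTiter-Glo, with a stated time of 5 days (on this read-out lower numbers stand for stronger inhibition and higher numbers for weaker inhibition), compound 2 has the lower of the two numbers, and its gap to compound 1 lies beyond the usual scatter. These two compounds differ in more than one place, so the gap cannot be tied to any single change.

The next compound is compound 3 (`CC/C(=C(/c1ccc(/C=C/C(=O)O)cc1)c1ccc2[nH]ncc2c1)c1ccc(C#N)cc1C`), which has 4-cyano-2-methylphenyl in place of 3-chlorophenyl on a double-bonded chain carbon bound to a double-bonded chain carbon and a saturated chain carbon. Going by the values given here, no measured pair isolates this replacement, so the data give no direct guide to its size or direction.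

With compound 2 at 12 nM as the lower of the two values, a modest move toward weaker inhibition is expected, possibly no larger than the scatter. The expected move is a 1.8-fold higher number from compound 2 to compound 3 (0.26 log units; within the scatter) in this assay as a working estimate. For compound 3 the estimated value is 22 nM (expected range 6 nM to 80 nM).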

Compound 3, half-maximal inhibitory concentration: 5 nM
For compound 3 the middle estimate is 4.4-fold (0.64 log units) above the measured one, and the stated range ends above it.
By their numbers in this assay, from the lowest: compound 3; then compound 2; then compound 1.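

In this assay, going by these compounds alone, putting 4-cyano-2-methylphenyl in place of 3-chlorophenyl on a double-bonded chain carbon bound to a double-bonded chain carbon and a saturated chain carbon gives a 2.4-fold lower number from compound 2 to compound 3 (0.38 log units; beyond the scatter), the first change that can be read in a single place. The aryl group at this position can therefore be exchanged without loss in this read-out, and here the exchange lowers the number even though the entering group has more heavy atoms and one hydrogen-bond acceptor where the leaving group has none. No measurement at hand bears on the reason for this step.

As far as these compounds go, the step swaps the chlorine for a nitrile and a methyl group together, so the shares of these two groups in the lower number stay open, and a single step gives neither a trend nor a limit at this position. Also open, from the compounds shown here alone, is how other substituents on this aryl group would read, for example a trifluoromethyl group, a methoxy group or an amine.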